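Hydroxy placement on the shared core

The compounds below may be only part of what the source reports. "The series", "measured", "known", "first", "only" and "open" are said of these compounds alone.

Compound 1 `O=C(/C=C/c1ccccc1F)c1ccccc1` sits only at a limit in a functional assay on RAW264.7 cells (Mus musculus) for inhibition, read by fluorescence, with stated times of 1 h, 24 h and 30 min; on this read-out higher numbers stand for weaker inhibition and lower numbers for stronger inhibition: compound 1 gives > 10000 nM, a limit of the assay and not a number. Compound 2 `O=C(/C=C/c1ccccc1F)c1ccccc1O` gives > 10000 nM in this assay, again a limit. The step that the two limits leave unreadable from compound 1 to compound 2 is thus unreadable; all the data show is the limit of > 10000 nM in this assay, at which 2 of the 2 values shown sit. Compound 3 `O=C(/C=C/c1ccccc1F)c1cccc(O)c1` differs from compound 1 by hydroxy in place of hydrogen on an aromatic carbon. Among the compounds with values here, no measured step bears readably on this change, so no step beyond the scatter is expected in either direction. Compound 3 is estimated at 20000 nM, ranging 5000 nM to 80000 nM. The expected step is a step that the limit leaves unreadable from compound 1 to compound 3, with compound 3 most likely reported again as a limit.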

Compound 3, half-maximal inhibitory concentration: > 10000 nM
Compound 3: a limit, no number (the forecaster's own chance of this, stated with the estimate: 80%); the middle value lies beyond the limit too.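

Within the data shown here, compound 1 and compound 3 both sit at a limit and not a number, so no step between them can be read. On these data alone, whether hydroxy in place of hydrogen on an aromatic carbon changes inhibition at all stays open for compound 2 and compound 3.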